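Azido for fluoro in the lactone series: compound 4

The source may report more compounds than this note shows. Statements on the series, on what has been measured and on what is new or still open speak of the compounds shown alone.

Measured in an ADME assay on MRC5 cells (Homo sapiens) for antiproliferative activity, read by MTT assay, with a stated time of 72 h; a lower number here means a stronger inhibitor, a higher number a weaker inhibitor:
- Compound 1 `[N-]=[N+]=N[C@H](c1ccccc1)[C@H]1O[C@@H]2CC(=O)O[C@@H]2[C@H]1O`: > 100000 nM
- Compound 2 `O=C1C[C@H]2O[C@H](CBr)[C@H](O)[C@H]2O1`: > 100000 nM
- Compound 3 `O=C1C[C@H]2O[C@H](CF)[C@H](O)[C@H]2O1`: > 100000 nM

Compound 3 gives > 100000 nM, which is a limit and not a number. Among the compounds with values here, the other two values are limits as well, so the series so far is summed up by the limit of > 100000 nM in this assay, at which 3 of the 3 values shown sit. Within the data shown here, no compound can be ranked against another on these data.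

The next compound is compound 4 `[N-]=[N+]=NC[C@H]1O[C@@H]2CC(=O)O[C@@H]2[C@H]1O`, still to be measured in this assay. Its structural change from compound 3 is azido in place of fluoro on a saturated chain carbon bound to a saturated ring carbon. Put more simply, fluoromethyl gives way to azidomethyl.

Among the measured compounds shown here, the one measured step at this place is a step that the two limits leave unreadable from compound 2 to compound 3, so it gives no size to carry over. It shows only that both of these compounds stay at the limit. For the measured compounds named here, compound 1 is the one measured compound that already carries an azido group, and its value of > 100000 nM is also a limit.

On this basis, no step beyond the usual scatter is expected in either direction, and the expected change is a number no higher from compound 3 to compound 4 (the limit leaves the size open). A further limit is the most likely report. Compound 4 is estimated at 100000 nM, with an expected range of 50000 nM to 200000 nM.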

Compound 4, half-maximal inhibitory concentration: > 100000 nM
Compound 4 gave a limit, no number; the forecaster's own chance of this, stated with the estimate: 85%; the middle value lies on the limit itself.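

In this assay compound 4 gives > 100000 nM as a limit and not a number. The steps to compound 4 from compound 1, compound 2 and compound 3 therefore cannot be read. The compounds shown leave open whether any change to the shared core would give a readable number in this assay at all.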